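A few compounds are considered here, and "the series" means these few. Any claim that something is new, unique, unknown or untested is made for them only; others in the source may bear on it.

Compound 2, `COc1ccc(-c2cc(C(=O)Nc3nc4ccccc4s3)nc3cc(-c4ccccc4)nn23)cc1`: 1540 nM in a functional assay on A549 cells (Homo sapiens) for cytotoxicity, read by MTT assay, with a stated time of 48 h; on this read-out lower numbers stand for stronger inhibition and higher numbers for weaker inhibition
Compound 1, `COc1ccc2nc(NC(=O)c3cc(-c4ccc(OC)c(OC)c4)n4nc(-c5ccccc5)cc4n3)sc2c1`: 15800 nM in this assay

Of the two compounds measured, compound 2 holds the lower number, and the gap to compound 1 lies beyond the scatter. Compound 1 differs from compound 2 in two places at once, so the two values alone cannot say which change carries the difference.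

Compound 3, `COc1ccc(-c2cc(C(=O)Nc3nc4ccccc4s3)nc3cc(-c4ccccc4)nn23)cc1OC`, has not yet been measured. It differs from compound 2 in one place only: methoxy in place of hydrogen on an aromatic carbon. This is one of the two changes that separate compound 1 from compound 2, so part of that larger gap may belong to it, but how much cannot be read from the numbers shown.

Compound 3 is therefore expected to show a modest weakening, a step of a 2.3-fold higher number from compound 2 to compound 3 (0.36 log units; beyond the scatter) in this assay. The estimate for compound 3 is 3500 nM, with a range from 1200 nM to 10000 nM.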

Compound 3, half-maximal inhibitory concentration: 5490 nM
Compound 3: middle estimate off by 1.6-fold (0.20 log units), on the low side, within the range that was stated.
By their numbers in this assay, from the lowest: compound 2; then compound 3; then compound 1.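

Placing a methoxy on this aromatic carbon, the one ortho to the existing methoxy, turns the 4-methoxyphenyl into a 3,4-dimethoxyphenyl and gives a 3.6-fold higher number from compound 2 to compound 3 (0.55 log units; beyond the scatter) in this assay, so this single change weakens the compound by itself. The other single change can now be read too: removing the remaining methoxy gives a 2.9-fold lower number from compound 1 to compound 3 (0.46 log units; beyond the scatter), which lies beyond the scatter as well. The gap between the two earlier compounds is thus shared between two places, and at each of them the compound carrying the extra methoxy holds the higher number.

Nothing shown explains why the added methoxy weakens the compound. On these data alone, it also stays open whether a smaller or different group on this carbon, such as a fluorine atom, a hydroxyl or an amine, would cost as much.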